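The compounds below may be only part of what the source reports. "The series", "measured", "known", "first", "only" and "open" are said of these compounds alone.

Compound 1 `CCNC(=O)c1noc(-c2cc(C(C)C)c(O)cc2O)c1-c1cc(CN)no1` is one of three close analogues that share a core carrying an ethylcarbamoyl group and a resorcinol bearing an isopropyl group; they differ only in the small aromatic ring attached next to the ethylcarbamoyl group. In a functional assay on HCT-116 cells (Homo sapiens) for inhibition (a higher number here means a weaker inhibitor, a lower number a stronger inhibitor), compound 1 gives 84 nM. Compound 3 `CCNC(=O)c1noc(-c2cc(C(C)C)c(O)cc2O)c1-c1cn[nH]c1` gives 43 nM, and the step of a 2.0-fold lower number from compound 1 to compound 3 (0.29 log units; within the scatter) lies within the scatter, so the two compounds cannot be told apart on these numbers. In this assay, going by the values given here, compound 2 `CCNC(=O)c1noc(-c2cc(C(C)C)c(O)cc2O)c1-c1cc(C(=O)OCC)no1` gives "not determined" (no result reported), so only two numbers exist, and compound 1 sits within the scatter of the other one.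

Compound 4 `CCNC(=O)c1noc(-c2cc(C(C)C)c(O)cc2O)c1-c1cnn(CC)c1` carries the change (1-ethyl-1H-pyrazol-4-yl in place of 3-(aminomethyl)-1,2-oxazol-5-yl on an aromatic carbon). Among the compounds with values here, the only measured step that bears on it is the one from compound 1 to compound 3, which placed a pyrazol-4-yl ring in the same position without any effect beyond the scatter. Within the data shown here, compound 4 adds an ethyl group on a ring nitrogen of that same pyrazole, and no measured pair tests such an addition here. The expectation is therefore a step of about a 1.2-fold lower number from compound 1 to compound 4 (0.08 log units; within the scatter), not beyond the scatter. Compound 4 is estimated at 70 nM, with a likely range from 25 nM to 200 nM.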

Compound 4, half-maximal inhibitory concentration: 26 nM
For compound 4 the middle estimate is 2.7-fold (0.43 log units) above the measured one; measured number inside the range.
By their numbers in this assay, from the lowest: compounds 4, 3 and 1 (each within the scatter of the next, the first and the last beyond it).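

In this assay, 1-ethyl-1H-pyrazol-4-yl in place of 3-(aminomethyl)-1,2-oxazol-5-yl gives a 3.2-fold lower number from compound 1 to compound 4 (0.51 log units; beyond the scatter), a modest step and the first at this position to lie beyond the scatter, so the choice of ring and its substituent can shift the number here. The ethyl group alone cannot be credited with that step: ethyl in place of hydrogen on the aromatic nitrogen gives a 1.7-fold lower number from compound 3 to compound 4 (0.22 log units; within the scatter), which is within the scatter, so the pyrazole with and without ethyl cannot be told apart, and the ethyl group is accepted there without a measurable loss. Nothing available explains why compound 4 differs from compound 1.

The compounds shown leave open whether a methyl group or a longer chain such as propyl on that ring nitrogen would separate clearly from compound 3. They also leave open whether a chain ending in an amine or a carboxylic acid at the same nitrogen would be accepted as the ethyl group is.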